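Working notes: from compound 2 to compound 3

A few compounds are considered here, and "the series" means these few. Any claim that something is new, unique, unknown or untested is made for them only; others in the source may bear on it.

Of the compounds shown here, two have numbers so far in a physicochemical assay for lipophilicity; a lower number here means a more polar compound, a higher number a more lipophilic compound. Compound 1 `COc1cc(/C=C2\CCC/C(=C\c3cccc([N+](=O)[O-])c3)C2=O)cc(OC)c1OC` gives 4.53. Compound 2 `O=C1/C(=C/c2ccc(F)cc2)CCC/C1=C\c1ccc([N+](=O)[O-])cc1` gives 5.09, the higher of the two numbers, and the gap between them lies beyond the usual scatter. These two compounds differ in more than one place, so their gap does not isolate any single structural change.

Compound 3 `Cc1ccc(/C=C2\CCC/C(=C\c3ccc([N+](=O)[O-])cc3)C2=O)cc1` has not yet been measured. It differs from compound 2 in one place only: methyl in place of fluoro on an aromatic carbon. This is methyl in place of fluoro on an aromatic carbon, and the same difference can be read as 4-fluorophenyl to 4-methylphenyl.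

Among the measured compounds shown here, the series holds no measured step for this change or any other single change, so the expectation rests on the structural change alone and remains loose. A modest rise in this assay is expected, near the edge of the usual scatter rather than clearly beyond it. The estimated change is a number 0.31 log units higher from compound 2 to compound 3 (beyond the scatter). For compound 3 the expected value is 5.4, with an estimated range from 5.05 to 5.75.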

Compound 3, partition coefficient: 5.38
Estimate against measurement, compound 3: 0.02 log units above; low and high end bracket the measured number.
By their numbers in this assay, from the lowest: compound 1; then compounds 2 and 3 (each within the scatter of the next).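

The series now has its first step that isolates a single change. In this assay, methyl in place of fluoro on an aromatic carbon of a six-membered aromatic ring of carbon only, para to a large group, gives a number 0.29 log units higher from compound 2 to compound 3 (within the scatter), so at this position the exchange of 4-fluorophenyl for 4-methylphenyl does not separate the two compounds by more than the scatter of the measurement. The gap between compound 1 and compound 2 could not show this, as those compounds differ in more than one place, and nothing on hand accounts for the size of the new step.

Still open, going by these compounds, is how this number responds at the same position to groups of a different kind, such as an amine, a carboxylic acid or a longer chain, since compound 2 and compound 3 carry only fluoro and methyl there. Also open, on these data alone, is whether methyl in place of fluoro gives a step of similar size elsewhere, as this single step speaks only for this one position on this one core.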